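Phenyl methyl placement: expectation for compound 3

The compounds below may be only part of what the source reports. "The series", "measured", "known", "first", "only" and "open" are said of these compounds alone.

Among the compounds with values here, in a functional assay on PC-3 cells (Homo sapiens) for cytotoxicity, read by MTT assay (a lower number here means a stronger inhibitor, a higher number a weaker inhibitor), compound 1 `Cc1cccc(Nc2nc(C)c(C(=O)/C=C/c3ccccc3Cl)s2)c1` gives 22200 nM and compound 2 `Cc1cccc(Nc2nc(C)c(C(=O)/C=C/c3ccccc3)s2)c1` gives 11700 nM, the lower of the two numbers, with compound 1 the nearest neighbour; the only measured step, a 1.9-fold lower number from compound 1 to compound 2 (0.28 log units; within the scatter), concerns the other aryl ring and does not touch the group changed next. Compound 3 `Cc1ccc(Nc2nc(C)c(C(=O)/C=C/c3ccccc3)s2)cc1` differs from compound 2 by 4-methylphenyl in place of 3-methylphenyl on a nitrogen on an aromatic ring. Within the data shown here, no measured step bears on this change, so no shift beyond the scatter is expected in this assay, the estimated step being a 1.0-fold higher number from compound 2 to compound 3 (0.01 log units; within the scatter). Compound 3 is therefore expected to give about 12000 nM, within 4000 nM to 36000 nM.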

Compound 3, half-maximal inhibitory concentration: > 25000 nM
Compound 3: only a limit was reported; the forecaster's own chance of this, stated with the estimate: 10%; middle value at least 2.0-fold (0.31 log units) from the limit.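

In this assay, the placement of the methyl group matters at this site: 4-methylphenyl in place of 3-methylphenyl on a nitrogen on an aromatic ring gives an at least 2.1-fold higher number from compound 2 to compound 3 (0.32 log units; beyond the scatter), although the two groups count the same atoms. Compound 3 gives > 25000 nM, which is a limit of the assay and not a number. The full size of the step therefore stays unknown, and the reading rests on a limit: the limit of > 25000 nM in this assay, at which 1 of the 3 values shown sits.

Open, going by these compounds, is how an unsubstituted phenyl, a 2-methylphenyl or a 4-methoxyphenyl would read on this nitrogen.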